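The source may hold more compounds than are shown below. What is called first, only, known or untested is meant among the compounds shown, and "the series" means these compounds.

Compound 2 `Cc1cc(C)cc(CSc2nc(C3CCCCC3)c(C#N)c(=O)[nH]2)c1` is the starting point of this account. In an assay on isolated protein for inhibition of Rap guanine nucleotide exchange factor 4 (Homo sapiens), read by fluorescence and cAMP accumulation (on this read-out higher numbers stand for weaker inhibition and lower numbers for stronger inhibition), compound 2 gives 7000 nM, the lowest of the two numbers recorded. Its nearest neighbour is compound 3 `Cc1cc(C)c(CSc2nc(C3CCCCC3)c(C#N)c(=O)[nH]2)c(C)c1`, which in this assay gives 11600 nM; the gap between the two lies within the scatter, so neither can be called the more potent. Compound 1 `N#Cc1c(C2CCCCC2)nc(S)[nH]c1=O` carries a free thiol rather than a thioether. In this assay compound 1 reaches only a limit of the assay, > 300000 nM, described as the limit of > 300000 nM in this assay, at which 1 of the 3 values shown sits.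

The step of interest leads from compound 2 to compound 4 `N#Cc1c(C2CCCCC2)nc(SCC(=O)O)[nH]c1=O`, which has not yet been measured. The change is carboxy in place of 3,5-dimethylphenyl on a saturated chain carbon bound to a sulfur, in words: carboxy in place of 3,5-dimethylphenyl on a saturated chain carbon bound to a sulfur. For the measured compounds named here, no measured pair shows a change of this kind. Both compounds with numbers carry a methylated aromatic ring on the chain bound to sulfur, whereas compound 1, with no group on sulfur at all, sits at the limit > 300000 nM in this assay. Compound 4 is therefore expected to inhibit more weakly, the step of a 14-fold higher number from compound 2 to compound 4 (1.15 log units; beyond the scatter) pointing toward higher numbers well beyond the scatter. Compound 4 is estimated at 100000 nM, with a range from 20000 nM to 300000 nM, and a fair chance that only a limit is returned.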

Compound 4, half-maximal inhibitory concentration: > 300000 nM
Compound 4 gave a limit, no number; the forecaster's own chance of this, stated with the estimate: 40%; middle value at least 3.0-fold (0.47 log units) from the limit.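

In this assay, for the compounds shown here, carboxy in place of 3,5-dimethylphenyl on a saturated chain carbon bound to a sulfur gives an at least 42-fold higher number from compound 2 to compound 4 (1.63 log units; beyond the scatter), the first direct one-place comparison at this position. Going by these compounds alone, the earlier compounds could suggest only that some group on sulfur was needed, whereas compound 4 shows that not just any group will do: with a carboxymethyl group on the sulfur, it returns no number, and the step from compound 1 to compound 4 cannot be read, as both ends of it are limits. Compound 4 therefore joins compound 1, which carries a free thiol, at the top of the measurable range: the limit of > 300000 nM in this assay, at which 2 of the 4 values shown sit.

The compounds shown leave open whether the loss of the aromatic ring or the arrival of the carboxy group accounts for the step, and a methyl ester or a cyclohexyl group on the same chain carbon would bear on that question. As far as these compounds go, it also remains open whether an unsubstituted phenyl ring on that carbon, or a longer chain ending in a carboxylic acid, would return a number at all.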